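Swapping a Urea for an Amide: What to Expect

This account rests on a few compounds, and the source may have more. Where it says the series, first, only, none or still open, it means among the compounds named here.

Compound 1, `COc1cc(-c2nn(-c3cccc(NC(=O)Nc4cc(C(F)(F)F)cc(C(F)(F)F)c4)c3)cc2-c2ccncc2)ccc1Cl`, gives 5720 nM in a functional assay on ACHN cells (Homo sapiens) for inhibition, read by sulforhodamine B assay, with a stated time of 48 h; a lower number here means a stronger inhibitor of growth, a higher number a weaker inhibitor of growth.
Compound 2, `COc1cc(-c2nn(-c3cccc(NC(=O)Nc4ccc(Cl)c(Cl)c4)c3)cc2-c2ccncc2)ccc1Cl`, gives only a limit, > 50000 nM.
Compound 3, `O=C(Nc1cccc(-n2cc(-c3ccncc3)c(-c3ccc(Cl)c(O)c3)n2)c1)Nc1ccc(Cl)c(Cl)c1`, likewise gives only a limit, > 32500 nM.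

Compound 2 thus stands at the weak end of the numbers shown: its value is a limit of the assay, not a number, so how far it lies from compound 1 cannot be read. Compound 4, `COc1cc(-c2nn(-c3cccc(NC(=O)c4ccc(Cl)c(C(F)(F)F)c4)c3)cc2-c2ccncc2)ccc1Cl`, has not yet been measured. It differs from compound 2 in one place: 4-chloro-3-(trifluoromethyl)phenyl in place of (3,4-dichlorophenyl)amino on a carbonyl carbon. In plainer words, the urea linker of compound 2 becomes an amide, and the ring on it carries a chlorine and a trifluoromethyl group instead of two chlorines.

Among the measured compounds shown here, only one measured step exists, a step that the two limits leave unreadable from compound 2 to compound 3, and its size is not readable due to the limit of > 50000 nM in this assay, at which 1 of the 3 values shown sits, and (the limit of > 32500 nM in this assay, at which 1 of the 3 values shown sits), where compound 2 and compound 3 sit. For the measured compounds named here, no measured step turns a urea into an amide, so nothing here shows the direction of the present change. Compound 1, with trifluoromethyl groups on its urea ring, does reach 5720 nM.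

Compound 4 is therefore expected to fall near 15000 nM, within 3000 nM to 50000 nM. The expected step is an at least 3.3-fold lower number from compound 2 to compound 4 (0.52 log units; beyond the scatter), its size not readable from a starting limit.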

Compound 4, concentration for total growth inhibition: > 32500 nM
Compound 4: only a limit was reported; the forecaster's own chance of this, stated with the estimate: 40%; middle value at least 2.1-fold (0.33 log units) from the limit.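

In this assay compound 4 gives > 32500 nM, which is a limit of the assay and not a number. Among the compounds shown here, compound 2 also gives only a limit, > 50000 nM, so no step between compound 2 and compound 4 can be read. The compounds shown leave open whether replacing the urea with an amide changes growth inhibition at all.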